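The compounds below may be only part of what the source reports. "The series", "measured", "known", "first", "only" and "open" are said of these compounds alone.

Working notes on the series.

Compound 1 `Cc1ccccc1Cn1c(CN2CCN(C(=O)C3CC3)CC2)nc2ccccc21` is the reference point. In an assay on isolated protein for inhibition of aldehyde dehydrogenase 1A1 (Homo sapiens), read by spectrophotometry, tested at 10 uM (a higher number here means more inhibition at the concentration tested (going by the name of the read-out), a lower number less inhibition), compound 1 gives 29.1%, the higher of the two numbers recorded so far. Compound 2 `Cc1cccc(Cn2c(CN3CCN(C(=O)c4ccc(F)cc4)CC3)nc3ccccc32)c1`, which carries a different arrangement of the methyl group on the benzyl ring and a different amide, gives 27.1% in this assay; the gap to compound 1 lies within the scatter, so the two read as one level rather than as an ordered pair.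

Compound 3 `CCCCn1c(CN2CCN(C(=O)C3CC3)CC2)nc2ccccc21` has not yet been measured in this assay. Against compound 1 the change is propyl in place of 2-methylphenyl on a saturated chain carbon bound to an aromatic nitrogen. Among the measured compounds shown here, no measured pair in the set isolates this change, so there is no directly comparable step to lean on; the only anchor is the value of compound 1 itself.

The working expectation is a modest fall rather than a gain: the aromatic ring is taken out and a short chain put in its place, and nothing in the set shows that this is neutral. The step from compound 1 to compound 3 is expected to be a number 8.1 percentage points lower from compound 1 to compound 3 (within the scatter), near the edge of the scatter. Compound 3 is therefore estimated at 21%, with a range from 6% to 36%.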

Compound 3, a percentage reported as inhibition, at one concentration (the size of the read-out at that concentration, not a potency): 18.2%
Beside the measured number, compound 3's estimate is 2.8 percentage points above it; low and high end bracket the measured number.
By their numbers in this assay, from the lowest: compounds 3, 2 and 1 (each within the scatter of the next, the first and the last beyond it).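

Among the compounds shown here, this is the first step that isolates the group on a saturated chain carbon bound to an aromatic nitrogen, with the rest of the molecule held constant. In this assay, propyl in place of 2-methylphenyl gives a number 10.9 percentage points lower from compound 1 to compound 3 (beyond the scatter), so the position is not indifferent to the group it carries, although the step is modest and compound 3 still gives 18.2% without the six-membered aromatic ring. The exchange removes the ring and reduces the group from 7 heavy atoms to 3 at the same time, so the step cannot assign the fall to either change, and nothing at hand bears on why the number falls.

Still open, from the compounds shown here alone, is whether a plain benzyl group or a cyclohexylmethyl group would stay at the level of compound 1 or fall to that of compound 3, and whether a longer chain such as hexyl would recover any of the difference. Going by these compounds, it is also open whether the same exchange gives a similar step when the cyclopropyl amide is replaced by the 4-fluorobenzoyl amide of compound 2.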